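The source may hold more compounds than are shown below. What is called first, only, known or untested is meant among the compounds shown, and "the series" means these compounds.

Measured so far:
Compound 1, `O=C(Nc1nnc(-c2ccc(Cl)cc2)s1)c1ccccc1`: in a functional assay on the whole organism (integument) for inhibition, with Chilo suppressalis as the target, read by scintillation counting, with a stated time of 72 h (a higher number here means a weaker inhibitor, a lower number a stronger inhibitor), compound 1 gives > 5010 nM, which is a limit of the assay and not a number.
Compound 2, `O=C(Nc1nnc(-c2ccc(Cl)cc2)s1)c1ccccc1Cl`: compound 2 gives > 5010 nM, again a limit rather than a number.

Compound 2 therefore stands at the limit of > 5010 nM in this assay, at which 2 of the 2 values shown sit, with no number of its own. Within the data shown here, the one step that reaches it, a step that the two limits leave unreadable from compound 1 to compound 2, cannot be sized, since both ends are limits. Compound 3, `O=C(Nc1nnc(-c2ccc(Cl)cc2)s1)c1ccccc1Br`, differs from compound 2 by bromo in place of chloro on an aromatic carbon. Among the measured compounds shown here, the only measured step that bears on this change is the unreadable one from compound 1 to compound 2, so there is nothing to fix a size or a direction. Compound 3 is expected to show no step beyond the scatter, a step that the limit leaves unreadable from compound 2 to compound 3, and most probably to return only a limit again. The estimate for compound 3 is 9000 nM, with a range from 3000 nM to 40000 nM.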

Compound 3, half-maximal inhibitory concentration: > 5010 nM
Compound 3: only a limit was reported; the forecaster's own chance of this, stated with the estimate: 80%; the middle value does not contradict the limit.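

Compound 3 returns only a limit, > 5010 nM, so the steps joining compound 1, compound 2 and compound 3 cannot be read, in size or in direction. The compounds shown leave open how strong any of them truly is in this assay, because all share one limit: the limit of > 5010 nM in this assay, at which 3 of the 3 values shown sit.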